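A few compounds are considered here, and "the series" means these few. Any claim that something is new, unique, unknown or untested is made for them only; others in the source may bear on it.

Measured compounds in a functional assay on MKN-74 cells (Homo sapiens) for antiproliferative activity, with a stated time of 24 h; a lower number here means a stronger inhibitor, a higher number a weaker inhibitor:
compound 1 `N#Cc1ccccc1CN1CCc2c(sc(NC(=O)c3ccccc3Cl)c2C(N)=O)C1`, giving 9500 nM
compound 2 `NC(=O)c1c(NC(=O)c2ccccc2F)sc2c1CCN(Cc1ccc(Cl)cc1Cl)C2`, giving 9610 nM
compound 3 `NC(=O)c1c(NC(=O)c2cccc([N+](=O)[O-])c2)sc2c1CCN(Cc1ccc(Cl)cc1Cl)C2`, giving 16500 nM

Compound 1 has the lowest of the three numbers, but its separation from compound 2 and from compound 3 lies within the scatter, so no order among the three can be read. Going by the values given here, the only single-point step in the set, a 1.7-fold higher number from compound 2 to compound 3 (0.23 log units; within the scatter), concerns the group on the carbonyl carbon and stays within the scatter.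

Compound 4 `CSc1ccccc1NC(=S)N1CCc2c(sc(NC(=O)c3ccccc3Cl)c2C(N)=O)C1` is not yet measured. It differs from compound 1 at the amine nitrogen in a ring: a group of 11 heavy atoms (8 carbon, 1 nitrogen, 2 sulfur; one six-membered aromatic ring of carbon only) in place of a group of 9 heavy atoms (8 carbon, 1 nitrogen; one six-membered aromatic ring of carbon only), on an amine nitrogen in a ring. Among the compounds with values here, none of the measured steps touches this position; the one step in hand bears on the carbonyl carbon only and gives no guidance here. Within the data shown here, with no relevant precedent, and all three measured numbers within scatter of one another, no step beyond the scatter is expected in this assay in either direction. The estimate for compound 4 is therefore 9500 nM, range 3000 nM to 30000 nM, meaning an expected step of no change at the digits printed from compound 1 to compound 4 (within the scatter).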

Compound 4, half-maximal inhibitory concentration: 13800 nM
Compound 4: middle estimate off by 1.5-fold (0.16 log units), on the low side, and the stated range covers the measured number.
By their numbers in this assay, from the lowest: compounds 1, 2, 4 and 3 (each within the scatter of the next).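

Going by these compounds alone, the amine nitrogen in a ring is touched here for the first time. Putting the group of 11 heavy atoms, with its double bond outside aromatic rings and its hydrogen-bond donor, in place of 2-cyanobenzyl gives a 1.5-fold higher number from compound 1 to compound 4 (0.16 log units; within the scatter) in this assay, so this exchange of two quite different groups at this position produces no step beyond the scatter. Nothing available bears on why this is so.

Still open, as far as these compounds go, is whether any group on this nitrogen can move the number beyond the scatter, for example a methyl, a longer alkyl chain or a benzyl carrying a carboxylic acid. Also open, from the compounds shown here alone, is whether the same exchange gives a similar step when a different group sits on the carbonyl carbon.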